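From cyclohexyl to pyridin-2-yl on the amide nitrogen

The source may hold more compounds than are shown below. What is called first, only, known or untested is meant among the compounds shown, and "the series" means these compounds.

In an ADME assay on MRC5 cells (Homo sapiens) for inhibition, with a stated time of 72 h (on this read-out lower numbers stand for an effect already at smaller amounts and higher numbers for an effect only at larger amounts of compound), compound 1 `CCCCCNC(=O)c1n[nH]cc1NC(=O)c1c(OC)cccc1OC` gives > 50000 nM as a limit of the assay and not a number. Compound 2 `COc1cccc(OC)c1C(=O)Nc1c[nH]nc1C(=O)NCCCN(C)C` likewise gives > 50000 nM as a limit only. Among the compounds with values here, compound 3 `COc1cccc(OC)c1C(=O)Nc1c[nH]nc1C(=O)NC1CCCCC1` gives 35000 nM and so holds the only actual number of the set. Compound 4 `COc1cccc(OC)c1C(=O)Nc1c[nH]nc1C(=O)Nc1ccccn1` carries pyridin-2-yl in place of the cyclohexyl of compound 3 on an amide-type nitrogen (pyridin-2-yl in place of cyclohexyl on an amide-type nitrogen). Two measured exchanges on that nitrogen bear on this (an at least 1.4-fold lower number from compound 1 to compound 3 (0.15 log units; that floor lies within the scatter); an at least 1.4-fold lower number from compound 2 to compound 3 (0.15 log units; that floor lies within the scatter)) and both floors lie within the scatter. On those two steps no change beyond the scatter is expected in this assay here. The estimated step is small (a 1.1-fold higher number from compound 3 to compound 4 (0.06 log units; within the scatter)). Compound 4 is expected at 40000 nM (estimated range 16000 nM to 70000 nM).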

Compound 4, half-maximal effective concentration: > 50000 nM
Compound 4: a limit, no number; the forecaster's own chance of this, stated with the estimate: 55%; middle value at least 1.2-fold (0.09 log units) away from the limit.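

Within the data shown here, on the amide-type nitrogen, pyridin-2-yl is the only group in this set with a ring hetero atom, and in this assay the exchange gives an at least 1.4-fold higher number from compound 3 to compound 4 (0.15 log units; that floor lies within the scatter), so no real change can be claimed. The steps to compound 4 from compound 1 and from compound 2 cannot be read, as both ends of each are limits. Compound 3 remains the only compound with an actual number, which leaves little of this position readable: the limit of > 50000 nM in this assay, at which 3 of the 4 values shown sit.

From the compounds shown here alone, whether phenyl or piperidin-4-yl on that nitrogen would give a number clearly lower than that of compound 3 stays open.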